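Swapping an ether for an amine on a flavone-like core

The source may hold more compounds than are shown below. What is called first, only, known or untested is meant among the compounds shown, and "the series" means these compounds.

Measured compounds:
- compound 1, `COc1cc(OC)c2c(=O)cc(-c3ccc(OCCN4CCCC4=O)cc3)oc2c1`, 33% in a functional assay (Homo sapiens) for antiproliferative activity, read by resazurin assay, with a stated time of 48 h, tested at 20 uM; on this read-out higher numbers stand for a stronger effect at the one concentration tested and lower numbers for a weaker effect
- compound 2, `COc1cc(OC)c2c(=O)cc(-c3ccc(OC4CCNCC4)cc3)oc2c1`, "not determined" (no result reported) in this assay

Compound 1 carries a chain ending in a pyrrolidinone and, in this assay, gives 33%. Compound 2 shares the core of compound 1 but has a (piperidin-4-yl)oxy group on the aromatic carbon instead; for compound 2 this assay reports "not determined" (no result reported), so it stands nowhere on the scale and offers no anchor. Compound 3, `COc1cc(OC)c2c(=O)cc(-c3ccc(NCCN4CCCC4)cc3)oc2c1`, is the unmeasured partner: (2-(pyrrolidin-1-yl)ethyl)amino in place of (piperidin-4-yl)oxy on an aromatic carbon. Within the data shown here, with no measured step between related pairs, the size and direction of any change from compound 2 to compound 3 in this assay cannot be read off the data; only the single value of compound 1 hints at the level such compounds reach. On that basis compound 3 is expected to give about 35%, most likely between 15% and 60%.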

Compound 3, a percentage reported as inhibition, at one concentration (the size of the read-out at that concentration, not a potency): 80%
Compound 3: middle estimate off by 45 percentage points, on the low side; measured number above the stated range.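

Changing the group on this aromatic carbon can move the result strongly in this assay and the change from 2-(2-oxopyrrolidin-1-yl)ethoxy to (2-(pyrrolidin-1-yl)ethyl)amino gives a number 47 percentage points higher from compound 1 to compound 3 (beyond the scatter) as the first measured sign of that. Any step involving compound 2 cannot be read, so this single step carries the whole comparison. Nothing measured here accounts for the rise.

This one step changes two things at once: the oxygen linking the chain to the aromatic ring becomes a nitrogen, and the carbonyl of the five-membered ring disappears. The compounds shown leave open which of these matters, and a 2-(pyrrolidin-1-yl)ethoxy group on the same carbon, which keeps the oxygen link but has no carbonyl, would help to separate the two.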